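A Fluoro Substituent Added to the Phenyl of Compound 2

A few compounds are considered here, and "the series" means these few. Any claim that something is new, unique, unknown or untested is made for them only; others in the source may bear on it.

Compound 1, `COc1ccc2cc(C(C)c3nnc4n3N=C(c3ccc(Cl)cc3Cl)CS4)ccc2c1`: 14600 nM
Compound 2, `CC(c1ccc(-c2ccccc2)c(F)c1)c1nnc2n1N=C(c1ccccc1)CS2`: 7400 nM
Compound 3, `CC(C)Cc1ccc(C(C)c2nnc3n2N=C(c2ccc(OC(F)(F)F)cc2)CS3)cc1`: 1100 nM

All three compounds share the same core and were tested in a functional assay on MCF7 cells (Homo sapiens) for inhibition, read by sulforhodamine B assay, with a stated time of 72 h; a higher number here means a weaker inhibitor, a lower number a stronger inhibitor. Compound 2 gives 7400 nM, the second highest of the three numbers. Its nearest neighbour is compound 1, whose 14600 nM lies within the scatter, so the two cannot be ordered. Compound 3, with 1100 nM, gives the lowest number and is separated from compound 2 beyond the scatter.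

Compound 4, `CC(c1ccc(-c2ccccc2)c(F)c1)c1nnc2n1N=C(c1ccc(F)cc1)CS2`, has not yet been measured. It differs from compound 2 in one place: fluoro in place of hydrogen on an aromatic carbon. Within the data shown here, none of the measured compounds differ from one another in only one place, so the data do not show what a single change of this kind does to the number. In this assay the expected change, a 1.2-fold lower number from compound 2 to compound 4 (0.09 log units; within the scatter), is small and not beyond the scatter in either direction. The expectation rests on compound 2 as the starting point, which gives 7400 nM. Compound 4 is therefore expected to give about 6000 nM, in a range from 2500 nM to 15000 nM.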

Compound 4, half-maximal inhibitory concentration: 8100 nM
Estimate against measurement, compound 4: 1.4-fold (0.13 log units) below; the measured number falls inside the stated range.
By their numbers in this assay, from the lowest: compound 3; then compounds 2, 4 and 1 (each within the scatter of the next).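

Among these compounds, compound 2 and compound 4 form the first pair here that differs in only one place, so they give the first direct reading of a change on this ring. In this assay, going from phenyl to 4-fluorophenyl gives a 1.1-fold higher number from compound 2 to compound 4 (0.04 log units; within the scatter), so a hydrogen and a fluoro on this aromatic carbon, para to a large group, cannot be told apart by this measurement. No measured evidence bears on why the two compounds read alike.

This single pair speaks for one small group at one position on one scaffold, and it does not say whether fluoro would read the same way on another carbon of this ring or on a ring of a different compound in the series. It also leaves open what a group of another kind on this same aromatic carbon would do to the number, such as an amine, a carboxylic acid or a longer chain like butyl, each of which would need its own one-place comparison with compound 2.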